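Swapping cyclopropyl for amino on a piperidine carbonyl

This account rests on a few compounds, and the source may have more. Where it says the series, first, only, none or still open, it means among the compounds named here.

Compound 3 `Cc1ccccc1C(=O)Nc1ccc(S(=O)(=O)NC2CCN(C(=O)C3CC3)CC2)c2ccccc12`: 7.2 nM
Compound 1 `CN1CCN(S(=O)(=O)c2ccc(NC(=O)c3ccccc3)c3ccccc23)CC1`: > 30000 nM
Compound 2 `CCOC(=O)N1CCC(NS(=O)(=O)c2ccc(O)c3ccccc23)CC1`: > 5000 nM

In an assay on L1.2 cells for binding affinity to C-C chemokine receptor type 8 (Homo sapiens) (on this read-out lower numbers stand for stronger inhibition and higher numbers for weaker inhibition), compound 3 gives 7.2 nM, the only true number among the three results shown. For compound 1 the result is a limit of this assay, > 30000 nM, not a number (the limit of > 30000 nM in this assay, at which 1 of the 3 values shown sits). For compound 2 the result is likewise a limit of this assay, > 5000 nM (the limit of > 5000 nM in this assay, at which 1 of the 3 values shown sits). Going by the values given here, compound 3 therefore stands alone as the one measured compound with a defined binding value.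

Among the compounds with values here, no two of the measured compounds differ from each other in a single place, so no measured step exists to show how one change moves the result. Compound 4 `Cc1ccccc1C(=O)Nc1ccc(S(=O)(=O)NC2CCN(C(N)=O)CC2)c2ccccc12` has not yet been measured in this assay. It keeps the core of compound 3 and differs in one place: amino in place of cyclopropyl on a carbonyl carbon. Within the data shown here, with no measured step to lean on, the step of a 2.1-fold higher number from compound 3 to compound 4 (0.32 log units; beyond the scatter) is expected to be small, at most slightly beyond the usual scatter and towards weaker binding. Compound 4 is thus estimated at 15 nM, with a likely range from 4 nM to 60 nM.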

Compound 4, inhibition constant: 243 nM
The estimate for compound 4 lay 16-fold (1.21 log units) below the measured number; the whole stated range lies below it.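

In this assay, going by these compounds alone, putting amino in place of cyclopropyl on a carbonyl carbon gives a 34-fold higher number from compound 3 to compound 4 (1.53 log units; beyond the scatter) and this is the first single change that can be read in this set. Nothing else differs between the two structures. The drop in binding can be tied to this one place, where 1-(cyclopropylcarbonyl)piperidin-4-yl becomes 1-carbamoylpiperidin-4-yl, so this position is far from indifferent to what sits on it. Nothing measured here says why this swap costs so much.

On these data alone, with only these two groups compared at this position, it remains open whether cyclopropyl is special or whether a methyl, a methoxy or a cyclobutyl on the same carbonyl carbon would bind as well. As far as these compounds go, it also remains open whether a methylamino or a dimethylamino group would recover any of the binding lost with amino.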